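Benzyl variants at the assay limit, with compound 4 next

The source may report more compounds than this note shows. Statements on the series, on what has been measured and on what is new or still open speak of the compounds shown alone.

Of the compounds shown here, three have been read in a functional assay on G-361 cells (Homo sapiens) for antiproliferative activity, with a stated time of 72 h; a lower number here means a stronger inhibitor, a higher number a weaker inhibitor. Compound 1 (`OC[C@H]1O[C@@H](n2cnc3c(NCc4ccc(F)cc4)ncnc32)[C@H](O)[C@@H]1O`) gives > 166000 nM as a limit and not a number. Compound 2 (`OC[C@H]1O[C@@H](n2cnc3c(NCc4c(F)ccc(F)c4F)ncnc32)[C@H](O)[C@@H]1O`) gives > 166000 nM as a limit too. Compound 3 (`Cc1cccc(CNc2ncnc3c2ncn3[C@@H]2O[C@H](CO)[C@@H](O)[C@H]2O)c1O`) gives > 166000 nM as a limit also. Compound 3 therefore has no number of its own and shares its place with the other two (the limit of > 166000 nM in this assay, at which 3 of the 3 values shown sit).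

Compound 4 (`OC[C@H]1O[C@@H](n2cnc3c(NCc4cccc(C(F)(F)F)c4)ncnc32)[C@H](O)[C@@H]1O`) carries 3-(trifluoromethyl)phenyl in place of 2-hydroxy-3-methylphenyl on a saturated chain carbon bound to a nitrogen on an aromatic ring. The measured steps at this same place give no size: there is a step that the two limits leave unreadable from compound 1 to compound 2 and a step that the two limits leave unreadable from compound 1 to compound 3 and also a step that the two limits leave unreadable from compound 2 to compound 3 to go on. Among the compounds with values here, none of them shows a direction, so no step of known size or direction is expected in this assay for this change. The most likely expected outcome is that compound 4 is also reported only as a limit. The expected step is an at least 1.1-fold lower number from compound 3 to compound 4 (0.04 log units; that floor lies within the scatter) as a rough estimate only. For compound 4 the estimated value is 150000 nM with an expected range from 50000 nM to 166000 nM in this series.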

Compound 4, half-maximal inhibitory concentration: > 166000 nM
Compound 4 gave a limit, no number (the forecaster's own chance of this, stated with the estimate: 85%); middle value at least 1.1-fold (0.04 log units) away from the limit.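

In this assay compound 4 gives > 166000 nM as a limit and not a number. The steps to compound 4 from compound 1, compound 2 and compound 3 therefore cannot be read, and all four compounds share one place: the limit of > 166000 nM in this assay, at which 4 of the 4 values shown sit. The compounds shown leave open whether any change to the benzyl group gives a measurable value in this assay and, if so, how the groups would rank.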